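Oxazolyl in Place of Chlorofuranyl on the Shared Core

The compounds below may be only part of what the source reports. "The series", "measured", "known", "first", "only" and "open" are said of these compounds alone.

Compound 1 `Nc1nc(-c2ccc(Cl)o2)nc2sc(CN3CCCCCC3)cc12`: 1420 nM
Compound 2 `Nc1nc(-c2ccc(Cl)o2)nc2sc(CN3CC=CC3)cc12`: 780 nM

In an assay on CHO-K1 cells for antagonist activity at adenosine receptor A1 (Homo sapiens), read by a beta-galactosidase reporter, with stated times of 15 min and 6 h (a lower number here means a stronger inhibitor, a higher number a weaker inhibitor), compound 2 gives 780 nM and compound 1 gives 1420 nM. Among the compounds with values here, the only measured step, a 1.8-fold lower number from compound 1 to compound 2 (0.26 log units; within the scatter), lies within the scatter, so the two compounds cannot be told apart on these numbers.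

Compound 3 `Nc1nc(-c2cocn2)nc2sc(CN3CC=CC3)cc12` has not been measured. It differs from compound 2 in one place: 1,3-oxazol-4-yl in place of 5-chlorofuran-2-yl on an aromatic carbon. That step touches the aromatic group on the core, whereas the measured step touched only the saturated ring on the chain. Within the data shown here, no measured step therefore bears on this change, and its size and direction cannot be read from the data.

With nothing to anchor it, the step is expected to be a 3.2-fold higher number from compound 2 to compound 3 (0.51 log units; beyond the scatter), and compound 3 is estimated at 2500 nM, with a wide range from 500 nM to 12000 nM in this assay.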

Compound 3, inhibition constant: 3900 nM
For compound 3 the middle estimate is 1.6-fold (0.19 log units) below the measured one, within the range that was stated.
By their numbers in this assay, from the lowest: compounds 2 and 1 (each within the scatter of the next); then compound 3.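

The group on the aromatic carbon between the two ring nitrogen atoms affects the number in this assay: 1,3-oxazol-4-yl in place of 5-chlorofuran-2-yl gives a 5.0-fold higher number from compound 2 to compound 3 (0.70 log units; beyond the scatter). Unlike the change of the saturated ring on the chain, which stayed within the scatter, this step lies beyond it, though it swaps several features at once, removing the chlorine and changing the ring from one hetero atom to two. No measurement shown here explains why the number rises.

The data leave open whether the chlorine or the ring itself accounts for the step, a question that an unsubstituted furanyl group at this place could help settle. A phenyl ring there would show how far this position tolerates a ring with no hetero atom at all.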